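Piperidine in Place of Amino on a Shared Core

This account rests on a few compounds, and the source may have more. Where it says the series, first, only, none or still open, it means among the compounds named here.

Measured so far:
Compound 1, `COc1cc2c(cc1OC)C(CC(N)=O)CC2`, gives 26.7% in a functional assay on the whole organism (strain Wistar) for inhibition, with Rattus norvegicus as the target, read by paw edema, with stated times of 60 min and 24 h, at a dose of 100 mg/kg by the oral route; a higher number here means more inhibition at the dose given (going by the name of the read-out), a lower number less inhibition.
Compound 2, `COc1cc2c(cc1OC)C(CC(=O)N1CCCC1)CC2`, gives 33.3% in this assay.

Compound 1 stands lowest of the two numbers, and its nearest neighbour is compound 2, with a step of a number 6.6 percentage points higher from compound 1 to compound 2 (within the scatter). Compound 3, `COc1cc2c(cc1OC)C(CC(=O)N1CCCCC1)CC2`, differs from compound 1 by piperidin-1-yl in place of amino on a carbonyl carbon. Going by the values given here, the one measured step that bears on this, pyrrolidin-1-yl in place of amino on the same carbonyl carbon, was a number 6.6 percentage points higher from compound 1 to compound 2 (within the scatter). A step of similar size is therefore expected in this assay, and the expected step is a number 7.3 percentage points higher from compound 1 to compound 3 (within the scatter). Compound 3 is estimated at 34%, in a range from 20% to 50%.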

Compound 3, a percentage reported as inhibition, in the whole organism at one dose (the size of the read-out at that dose, not a potency): 40%
Beside the measured number, compound 3's estimate is 6 percentage points below it, within the range that was stated.
By their numbers in this assay, from the lowest: compounds 1, 2 and 3 (each within the scatter of the next, the first and the last beyond it).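

Piperidin-1-yl in place of amino gives the first step on this carbonyl carbon that clears the scatter in this assay with a number 13.3 percentage points higher from compound 1 to compound 3 (beyond the scatter) and so shows that a modest gain can be read at this position. The two rings themselves stay unseparated, with a number 6.7 percentage points higher from compound 2 to compound 3 (within the scatter) between them. Nothing available gives a reason for the larger step.

The compounds shown leave open how morpholin-4-yl or an open-chain diethylamino group on the same carbonyl carbon would read. They also leave open what a carboxylic acid in place of the amide would give.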